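Methyl on the aromatic nitrogen of compound 3

A few compounds are considered here, and "the series" means these few. Any claim that something is new, unique, unknown or untested is made for them only; others in the source may bear on it.

Values in a functional assay on HT-29 cells (Homo sapiens) for inhibition; a lower number here means a stronger inhibitor, a higher number a weaker inhibitor:
- compound 1 `Oc1ccc(/C=C/c2ccc3ccccc3c2)cc1`: 4060 nM
- compound 2 `C(=C\c1cccc2ccccc12)\c1ccc2ccccc2c1`: 3570 nM
- compound 3 `C(=C\c1ccc2[nH]ccc2c1)\c1ccc2ccccc2c1`: > 5000 nM (a limit)

Compound 1 at 4060 nM and compound 2 at 3570 nM lie within the usual scatter of each other.

Compound 3 has only a limit, > 5000 nM, and no numerical value. As far as these compounds go, its place relative to compound 1 and compound 2 therefore remains open.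

The next compound, compound 4 `Cn1ccc2cc(/C=C\c3ccc4ccccc4c3)ccc21`, has methyl in place of hydrogen on an aromatic nitrogen. Going by the values given here, the series holds no measured example of this change, so its direction in this assay cannot be read from the data. No step beyond the scatter is expected, and compound 4 may also return only a limit.

The estimated step is an at least 1.1-fold lower number from compound 3 to compound 4 (0.04 log units; that floor lies within the scatter).

For compound 4 the expected value is 4500 nM.

The expected range for compound 4 runs from 1800 nM to 10000 nM.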

Compound 4, half-maximal inhibitory concentration: > 5000 nM
Compound 4: only a limit was reported; the forecaster's own chance of this, stated with the estimate: 50%; at least 1.1-fold (0.04 log units) between middle value and limit.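

Compound 3 and compound 4 both stand only as limits in this assay, so no step can be read between them: the limit of > 5000 nM in this assay, at which 2 of the 4 values shown sit.

The compounds shown leave open whether methyl in place of hydrogen on an aromatic nitrogen changes inhibition, and where compound 3 and compound 4 stand relative to compound 1 and compound 2.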